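This account rests on a few compounds, and the source may have more. Where it says the series, first, only, none or still open, it means among the compounds named here.

Compounds measured so far:

Compound 1, `Cc1[nH]c2ccc(Br)cc2c1C1=CCNCC1`, 10 nM in an assay on HEK293 cells for displacement of a labelled ligand from 5-hydroxytryptamine receptor 6 (Homo sapiens), read by scintillation counting, with a stated time of 1 h; a lower number here means a stronger inhibitor, a higher number a weaker inhibitor
Compound 2, `Cc1[nH]c2ccccc2c1C1=CCNCC1`, 200 nM in this assay
Compound 3, `Cc1[nH]c2ccc([N+](=O)[O-])cc2c1C1=CCNCC1`, 10 nM in this assay

Compound 3 stands level with compound 1 at the digits printed, the two together at the low end of the three numbers; compound 2 is the furthest from it, as the step of a 20-fold lower number from compound 2 to compound 3 (1.30 log units; beyond the scatter) shows. Compound 4, `Cc1[nH]c2ccc(OC(C)C)cc2c1C1=CCNCC1`, differs from compound 3 by isopropoxy in place of nitro on an aromatic carbon.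

Two of the measured steps bear on this change. The step of no change at the digits printed from compound 1 to compound 3 (within the scatter) shows that two quite different groups at this aromatic carbon give the same number, while the steps of a 20-fold higher number from compound 1 to compound 2 (1.30 log units; beyond the scatter) and a 20-fold lower number from compound 2 to compound 3 (1.30 log units; beyond the scatter) show that an unsubstituted carbon there costs a great deal. Isopropoxy is a third kind of group at the same carbon, so the expectation is a number between these extremes, closer to compound 3 than to compound 2. Compound 4 is therefore estimated at 30 nM, with a range of 5 nM to 150 nM, an expected step of a 3.0-fold higher number from compound 3 to compound 4 (0.48 log units; beyond the scatter).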

Compound 4, half-maximal inhibitory concentration: 100 nM
Beside the measured number, compound 4's estimate is 3.3-fold (0.52 log units) below it; low and high end bracket the measured number.
By their numbers in this assay, from the lowest: compounds 1 and 3 (each within the scatter of the next); then compounds 4 and 2 (each within the scatter of the next).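

Compound 4 shows that the low number at this aromatic carbon does not follow from having just any group there: bromo and nitro gave the same number, but isopropoxy does not join them, with a 10-fold higher number from compound 3 to compound 4 (1.00 log units; beyond the scatter) and a 10-fold higher number from compound 1 to compound 4 (1.00 log units; beyond the scatter) as the two steps. Against the unsubstituted compound, the reading is a 2.0-fold lower number from compound 2 to compound 4 (0.30 log units; within the scatter), so here isopropoxy cannot be told apart from hydrogen. Nothing measured on these compounds explains why isopropoxy parts from bromo and nitro.

On these data alone, whether methoxy, an amine or a nitrile at this carbon would stand with compound 1 and compound 3 or with compound 2 and compound 4 remains open. As far as these compounds go, it is also open whether a group at another carbon of the shared core would give steps of this size.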